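The source may hold more compounds than are shown below. What is called first, only, known or untested is meant among the compounds shown, and "the series" means these compounds.

Three compounds built on one shared core are compared in a functional assay on the whole organism with Rattus norvegicus as the target, at a dose of 20 mg/kg by the oral route; on this read-out lower numbers stand for less inhibition and higher numbers for more inhibition at the one dose given (going by the name of the read-out). Compound 1 `CNC(=O)/C=C1\CCc2ccc(Br)cc21` gives 44%. For the measured compounds named here, compound 2 `O=C(/C=C1\CCc2ccc(F)cc21)NCC1CC1` gives 0%, the lowest of the two numbers so far; its nearest neighbour, compound 1, stands well higher, a gap beyond the usual scatter. Compounds 1 and 2 differ in two places at once, so that pair alone cannot tell what a single change does. Compound 3 `CCNC(=O)/C=C1\CCc2ccc(F)cc21` has not yet been measured in this assay. It differs from compound 2 in one place: methyl in place of cyclopropyl on a saturated chain carbon bound to an amide-type nitrogen. Going by the values given here, no measured pair shows this change by itself, so the expectation leans only on compound 1, whose methyl amide gives the higher reading of the two. A moderate rise is therefore expected, a number 20 percentage points higher from compound 2 to compound 3 (beyond the scatter), though a step no larger than the scatter would not surprise. Compound 3 is estimated at 20%, within a range from 0% to 45%.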

Compound 3, a percentage reported as inhibition, in the whole organism at one dose (the size of the read-out at that dose, not a potency): 45%
Compound 3: middle estimate off by 25 percentage points, on the low side; the range from low to high includes it.
By their numbers in this assay, from the lowest: compound 2; then compounds 1 and 3 (each within the scatter of the next).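

In this assay, putting methyl in place of cyclopropyl on a saturated chain carbon bound to an amide-type nitrogen gives a number 45 percentage points higher from compound 2 to compound 3 (beyond the scatter) as a large step. For the compounds shown here, this is the first change at this position seen by itself, and it shows that the group on the amide-type nitrogen can alone separate a clear reading from none: with the rest of the molecule unchanged, ethyl gives inhibition where cyclopropylmethyl gives none. Nothing available explains why this swap matters so much.

Going by these compounds, whether a propyl chain, or a chain ending in an amine or a carboxylic acid, would read like ethyl or like cyclopropylmethyl remains open. Also open, on these data alone, is whether the same swap would have a similar effect on a core carrying bromine, as in compound 1.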